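A few compounds are considered here, and "the series" means these few. Any claim that something is new, unique, unknown or untested is made for them only; others in the source may bear on it.

Measured in a functional assay on MGC-803 cells (Homo sapiens) for antiproliferative activity, read by CCK-8 assay, with a stated time of 72 h; on this read-out lower numbers stand for stronger inhibition and higher numbers for weaker inhibition:
compound 1 `Nc1ccccc1NC(=O)c1ccc(CN2CCc3cc(Br)ccc32)cc1`: 7390 nM
compound 2 `Nc1ccccc1NC(=O)c1ccc(COc2ccccc2)cc1`: 5670 nM

Compound 2 stands within the scatter of compound 1, so these two values do not separate.

Compound 3 `CCCc1ccc(OCc2ccc(C(=O)Nc3ccccc3N)cc2)cc1` keeps the structure of compound 2 but has propyl in place of hydrogen on an aromatic carbon, para to a large group, which turns phenyl to 4-propylphenyl (propyl in place of hydrogen on an aromatic carbon). Among the measured compounds shown here, no measured pair shows this change, so the expectation rests on little. Compound 1 at 7390 nM and compound 2 at 5670 nM differ widely in structure yet stay within the scatter of each other. Only a small step is therefore expected in this assay, tentatively towards stronger inhibition. The expected change is a 1.6-fold lower number from compound 2 to compound 3 (0.21 log units; within the scatter), which may not clear the scatter. For compound 3 the estimated value is 3500 nM, with an expected range from 1000 nM to 10000 nM.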

Compound 3, half-maximal inhibitory concentration: 4420 nM
Compound 3: middle estimate off by 1.3-fold (0.10 log units), on the low side; the measured number falls inside the stated range.
By their numbers in this assay, from the lowest: compounds 3, 2 and 1 (each within the scatter of the next).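

In this assay, among the compounds shown here, the change from phenyl to 4-propylphenyl gives a 1.3-fold lower number from compound 2 to compound 3 (0.11 log units; within the scatter) as the first reading on this position. The aromatic carbon para to a large group thus carries propyl, with its 3 heavy atoms, and the number stays within the scatter, although this rests on one pair. No measured property is available to account for this result.

From the compounds shown here alone, it remains open whether an amine, a carboxylic acid or a longer chain such as hexyl at this position would give a step beyond the scatter. Also open, going by these compounds, is how a small group such as methoxy or a chlorine atom would read here, and whether the flat response to propyl holds for other substituents on this ring.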